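The source may report more compounds than this note shows. Statements on the series, on what has been measured and on what is new or still open speak of the compounds shown alone.

Working notes on the acrylonitrile series. Compound 1 `N#C/C(=C\c1c(F)c(F)c(F)c(F)c1F)C(=O)c1c[nH]c2ccccc12` and compound 2 `COc1ccc(CNC(=O)/C(C#N)=C/c2ccc(C)o2)cc1` have both been run in a functional assay on SMA cells (Homo sapiens) for inhibition, read by MTT assay, with a stated time of 72 h; a higher number here means a weaker inhibitor of growth, a lower number a stronger inhibitor of growth. In this assay compound 1 gives 20000 nM. In this assay compound 2 gives 69000 nM, the higher of the two numbers and the weaker growth inhibition recorded so far. Compound 3 `COc1ccc(CNC(=O)/C(C#N)=C/c2ccc(Cl)cc2)cc1` differs from compound 2 by 4-chlorophenyl in place of 5-methylfuran-2-yl on a double-bonded chain carbon bound to a double-bonded chain carbon. No comparable replacement has been measured within this set, so the size of any shift is open; a modest drop in the number is the working expectation, of the order of a 1.7-fold lower number from compound 2 to compound 3 (0.24 log units; within the scatter). For compound 3 the estimated value in this assay is 40000 nM, expected between 12000 nM and 120000 nM.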

Compound 3, concentration for 50% growth inhibition: 17000 nM
Beside the measured number, compound 3's estimate is 2.4-fold (0.37 log units) above it, and the stated range covers the measured number.
By their numbers in this assay, from the lowest: compounds 3 and 1 (each within the scatter of the next); then compound 2.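

In this assay, 4-chlorophenyl in place of 5-methylfuran-2-yl gives a 4.1-fold lower number from compound 2 to compound 3 (0.61 log units; beyond the scatter), the first step measured in this series, so growth inhibition responds to the group carried on a double-bonded chain carbon bound to a double-bonded chain carbon. No measured evidence bears on the reason for this step.

With a single replacement at this place, the compounds shown cannot separate the contribution of the chlorine from that of the six-membered ring itself. On these data alone, whether an unsubstituted phenyl or a pyridine ring would keep the step remains open.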